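A few compounds are considered here, and "the series" means these few. Any claim that something is new, unique, unknown or untested is made for them only; others in the source may bear on it.

Compound 1 `CS/C(=N\C(=O)c1csc([N+](=O)[O-])c1)NC(=O)c1csc([N+](=O)[O-])c1` was tested in a functional assay on HT-29 cells (Homo sapiens) for cytotoxicity, read by MTT assay, with a stated time of 72 h (a lower number here means a stronger inhibitor of growth, a higher number a weaker inhibitor of growth), where compound 1 gives 51800 nM. Among the measured compounds shown here, only one other compound has a number in this assay: compound 2 `O=C(/N=C(/NC(=O)c1ccno1)[Se]Cc1ccccc1)c1ccno1`, which in this assay gives 6820 nM. For the measured compounds named here, of these two numbers, the one for compound 1 is the higher, and the gap to compound 2 lies beyond the usual scatter, so compound 1 is the weaker growth inhibitor of the pair. Going by the values given here, compound 2 differs from compound 1 in more than one place, so its value shows only that a selenium-bearing compound of this family can reach a lower number; it does not isolate any single change.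

Compound 3 `C[Se]/C(=N\C(=O)c1csc([N+](=O)[O-])c1)NC(=O)c1csc([N+](=O)[O-])c1` keeps the core of compound 1 and changes one thing: a group of 2 heavy atoms (1 carbon, 1 selenium; no ring) in place of a group of 2 heavy atoms (1 carbon, 1 sulfur; no ring), on a carbon with a double bond to nitrogen. Among the compounds with values here, no pair of measured compounds differs in this one place alone, so there is no measured step to lean on. The expectation is a small move toward a lower number, or none beyond the scatter, giving an estimated step of a 1.7-fold lower number from compound 1 to compound 3 (0.24 log units; within the scatter). Compound 3 is therefore expected to give about 30000 nM, within a range from 10000 nM to 90000 nM.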

Compound 3, concentration for 50% growth inhibition: 0.63 nM
Estimate against measurement, compound 3: 48000-fold (4.68 log units) above, outside the stated range (below it).
By their numbers in this assay, from the lowest: compound 3; then compound 2; then compound 1.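

In this assay, replacing the methylsulfanyl group with its selenium counterpart, on a carbon with a double bond to nitrogen, gives an 82000-fold lower number from compound 1 to compound 3 (4.91 log units; beyond the scatter) while the rest of the molecule stays the same. Among the compounds shown here, this is the first measured step that isolates this place, and it shows that exchanging one sulfur atom for one selenium atom, with the group's count of heavy atoms unchanged, can by itself move the number enormously, something the earlier pair could not show because those compounds differ in more than one place. Nothing measured here explains why so small a change has so large a result.

As far as these compounds go, the size of this effect rests on a single pair of compounds, so it remains open whether the same exchange would do as much on a different core or with a longer chain, such as an ethyl group, on the selenium. From the compounds shown here alone, it is also open how a methoxy group or an amine would read at this same place, which would help show whether selenium itself is essential or whether other replacements for the sulfur could also reach such low numbers.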